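Ether variation on the urea series, compound 4 projected

The source may hold more compounds than are shown below. What is called first, only, known or untested is meant among the compounds shown, and "the series" means these compounds.

In a functional assay on RS4-11 cells (Homo sapiens) for inhibition, read by CCK-8 assay, with a stated time of 48 h (a higher number here means a weaker inhibitor, a lower number a stronger inhibitor), compound 1 `O=C(NCCNS(=O)(=O)c1ccc(-c2ccccc2O[C@H]2CC[C@H](O)CC2)s1)Nc1cc(Cl)cc(Cl)c1` gives 14100 nM, the highest of the three numbers measured. Compound 2 `Cc1ccc(-c2ccsc2S(=O)(=O)NCCNC(=S)Nc2cc(C(F)(F)F)cc(C(F)(F)F)c2)c(Oc2ccc(O)c(O)c2)c1` gives 4800 nM in this assay, and compound 3 `O=[N+]([O-])c1ccc(NC(=S)NCCNS(=O)(=O)c2ccc(-c3ccccc3O[C@H]3CC[C@H](O)CC3)s2)cc1` gives 1500 nM. For the measured compounds named here, the only single-point step recorded is a 9.4-fold lower number from compound 1 to compound 3 (0.97 log units; beyond the scatter), which concerns the group on the amine nitrogen and leaves the ether side untouched.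

Compound 4 `O=C(NCCNS(=O)(=O)c1ccc(-c2ccccc2OCc2cccc(O)c2)s1)Nc1cc(Cl)cc(Cl)c1` is not yet measured. It differs from compound 1 at the ether: 3-hydroxybenzyl in place of 4-hydroxycyclohexyl on an oxygen on an aromatic ring.

Going by the values given here, no measured step bears directly on this change. Compound 2 also carries an aromatic ether in place of the saturated ring, yet it differs from compound 1 at several further places, so its value says nothing clean about the ether alone. With only this to go on, the expected step of a 1.6-fold lower number from compound 1 to compound 4 (0.19 log units; within the scatter) is small, and the direction is uncertain. The estimate for compound 4 in this assay is therefore set close to compound 1, at 9000 nM, with a wide range from 2500 nM to 35000 nM, pending the actual measurement.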

Compound 4, half-maximal inhibitory concentration: > 50000 nM
Compound 4 was reported as a limit (the forecaster's own chance of this, stated with the estimate: 10%); at least 5.5-fold (0.74 log units) between middle value and limit.
By their numbers in this assay, from the lowest: compound 3; then compound 2; then compound 1. At a limit, above all of these: compound 4.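

For the compounds shown here, replacing 4-hydroxycyclohexyl with 3-hydroxybenzyl on the oxygen gives an at least 3.5-fold higher number from compound 1 to compound 4 (0.54 log units; beyond the scatter) in this assay, the first single-place step at this ether, and it shows that activity is sensitive to the group there, whereas the earlier step concerned only the group on the amine nitrogen. The result for compound 4 is a limit of the assay and not a number: the limit of > 50000 nM in this assay, at which 1 of the 4 values shown sits. The leaving and entering groups match in their counts of hydrogen-bond donors and acceptors and in net charge, so those counts do not separate compound 1 from compound 4, while the ring type, the defined stereocentres and the heavy-atom count do differ.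

As far as these compounds go, this single step changes all of those features together, so it remains open which of them, or which placement of the hydroxyl on the ring, governs the result. Also open, from the compounds shown here alone, are how this position responds when an amine or a carboxylic acid replaces the hydroxyl, and whether 3-hydroxybenzyl gives a similar step alongside the group on the amine nitrogen of compound 3.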